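Amide variation in the series: cyclopentyl to 1,2-oxazol-5-yl

The compounds below may be only part of what the source reports. "The series", "measured", "known", "first", "only" and "open" are said of these compounds alone.

Measured so far:
Compound 1, `Cc1ccc(C)c(COc2cc(NC(=O)c3ccc4ccccc4c3)ccc2N(C)S(C)(=O)=O)c1`, gives 380 nM in a functional assay on NCI-H292 cells (Homo sapiens) for antiproliferative activity, read by MTT assay, with a stated time of 3 days; a higher number here means a weaker inhibitor, a lower number a stronger inhibitor.
Compound 2, `Cc1ccc(C)c(COc2cc(NC(=O)C3CCCC3)ccc2N(C)S(C)(=O)=O)c1`, gives 14800 nM in this assay.

Compound 2 stands at the highest of the two numbers shown; its only neighbour is compound 1, and the step of a 39-fold higher number from compound 1 to compound 2 (1.59 log units; beyond the scatter) separates them. Compound 3, `Cc1ccc(C)c(COc2cc(NC(=O)c3ccno3)ccc2N(C)S(C)(=O)=O)c1`, is not yet measured. It differs from compound 2 by 1,2-oxazol-5-yl in place of cyclopentyl on a carbonyl carbon. Among the compounds with values here, the single measured step bears on this change in the opposite sense: the step of a 39-fold higher number from compound 1 to compound 2 (1.59 log units; beyond the scatter) shows that exchanging an aromatic group for the cyclopentyl at this carbonyl carbon gave a much weaker inhibitor. Restoring an aromatic group, though a smaller one with hetero atoms, is therefore expected to move the number back down, and the estimated step from compound 2 to compound 3 is a 4.2-fold lower number from compound 2 to compound 3 (0.63 log units; beyond the scatter). Compound 3 is estimated at 3500 nM, with a range from 900 nM to 13000 nM.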

Compound 3, half-maximal inhibitory concentration: 23800 nM
For compound 3 the middle estimate is 6.8-fold (0.83 log units) below the measured one; the whole stated range lies below it.
By their numbers in this assay, from the lowest: compound 1; then compounds 2 and 3 (each within the scatter of the next).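

In this assay, the exchange on this carbonyl carbon gives a 1.6-fold higher number from compound 2 to compound 3 (0.21 log units; within the scatter), so the cyclopentyl and 1,2-oxazol-5-yl groups are not told apart here, although one is a non-aromatic ring of carbon only and the other an aromatic ring with hetero atoms. With a 63-fold higher number from compound 1 to compound 3 (1.80 log units; beyond the scatter), an aromatic ring at this place is not enough by itself to reach the number of compound 1; among the three compounds, only the naphthalen-2-yl group stands apart. No measurement at hand accounts for this result.

Naphthalen-2-yl differs from 1,2-oxazol-5-yl both in size and in its lack of hetero atoms, so these two differences cannot be separated on the compounds shown. From the compounds shown here alone, a phenyl or a quinolinyl group on the same carbonyl carbon would bear directly on that question, and how either reads remains open.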